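Benzyl Amide in Place of Anisidide on a Furan Core

The compounds below may be only part of what the source reports. "The series", "measured", "known", "first", "only" and "open" are said of these compounds alone.

Measured compounds:
compound 1, `C=CC1=C(C(=O)Nc2ccccc2OC)C(c2ccc(F)cc2)OC1`: > 100000 nM
compound 2, `C=CC1=C(C(=O)NCCCCC)C(c2ccc(OC)cc2)OC1`: 36500 nM

Of the compounds shown here, two sharing the same core have been tested in a functional assay on A549 cells (Homo sapiens) for cytotoxicity, read by MTT assay, with a stated time of 24 h; a higher number here means a weaker inhibitor, a lower number a stronger inhibitor. Compound 1 is known only by a limit: in this assay compound 1 gives > 100000 nM, a value that is a limit of the assay rather than a number, which is the limit of > 100000 nM in this assay, at which 1 of the 2 values shown sits. Compound 2, which carries a pentyl amide and a methoxy group on its aryl ring, gives 36500 nM in this assay. The two compounds differ in more than one place, so their values are stated side by side without a step between them.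

Compound 3 `C=CC1=C(C(=O)NCc2ccccc2)C(c2ccc(F)cc2)OC1` has not yet been measured. It differs from compound 1 in one place: benzyl in place of 2-methoxyphenyl on an amide-type nitrogen. Because compound 1 stands at a limit, the size of the step can only be guessed; a modest step toward a stronger inhibitor in this assay is expected, though a result sitting again at the limit would not be surprising. Compound 3 is estimated at 60000 nM, with a likely range from 20000 nM to 150000 nM. This estimate corresponds to an expected step of an at least 1.6-fold lower number from compound 1 to compound 3 (0.22 log units; that floor lies within the scatter).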

Compound 3, half-maximal inhibitory concentration: > 100000 nM
Compound 3 ended at the assay's limit (the forecaster's own chance of this, stated with the estimate: 35%); middle value at least 1.6-fold (0.22 log units) from the limit.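

In this assay compound 3 gives > 100000 nM, which is a limit of the assay and not a number. Among these compounds, compound 1 also stands at a limit, so no step from compound 1 to compound 3 can be read: the limit of > 100000 nM in this assay, at which 2 of the 3 values shown sit. From the compounds shown here alone, whether benzyl in place of 2-methoxyphenyl on an amide-type nitrogen changes the value in this assay remains open.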